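From oxetan-3-yl to (oxolan-3-yl)methyl on an aromatic nitrogen

The compounds below may be only part of what the source reports. "The series", "measured", "known", "first", "only" and "open" are said of these compounds alone.

In a functional assay on HT-29 cells (Homo sapiens) for inhibition, read by luminescence and CellTiter-Glo, with a stated time of 24 h (a lower number here means that less compound is needed, a higher number that more compound is needed for the effect), compound 1 `CN1C(=S)[C@@H](NC(=O)c2nc(Cc3ccccc3)n(CCCCC#N)n2)COc2ccccc21` gives 2680 nM and compound 2 `CN1C(=S)[C@@H](NC(=O)c2nc(Cc3ccccc3)n(C3COC3)n2)COc2ccccc21` gives 916 nM, the lower of the two numbers. Compound 3 `CN1C(=S)[C@@H](NC(=O)c2nc(Cc3ccccc3)n(CC3CCOC3)n2)COc2ccccc21` carries (oxolan-3-yl)methyl in place of oxetan-3-yl on an aromatic nitrogen. Going by the values given here, the only measured step at this place, a 2.9-fold lower number from compound 1 to compound 2 (0.47 log units; beyond the scatter), was modest, with oxetan-3-yl in place of 4-cyanobutyl. It is a single guide, and the entering group appears in neither measured compound. A small step toward a higher number is therefore expected, a 1.6-fold higher number from compound 2 to compound 3 (0.21 log units; within the scatter). Compound 3 is estimated at 1500 nM, with a range of 600 nM to 4000 nM.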

Compound 3, half-maximal effective concentration: 4420 nM
The estimate for compound 3 lay 2.9-fold (0.47 log units) below the measured number; the whole stated range lies below it.
By their numbers in this assay, from the lowest: compound 2; then compounds 1 and 3 (each within the scatter of the next).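

In this assay, the step from oxetan-3-yl to (oxolan-3-yl)methyl on the aromatic nitrogen is a 4.8-fold higher number from compound 2 to compound 3 (0.68 log units; beyond the scatter), so carrying a non-aromatic ring with one oxygen at this position does not by itself keep the lower number of compound 2. Compound 3, with that ring, and compound 1, with its open nitrile chain, show a 1.6-fold higher number from compound 1 to compound 3 (0.22 log units; within the scatter). Nothing available here accounts for these differences.

Going by these compounds, it remains open whether ring size or the added methylene carries the step. Neither oxolan-3-yl bound directly to the nitrogen nor a small amine such as azetidin-3-yl appears among the compounds shown.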